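Notes on amide-capped purine series: estimate for compound 4

The compounds below may be only part of what the source reports. "The series", "measured", "known", "first", "only" and "open" are said of these compounds alone.

In a functional assay on HCT-116 cells (Homo sapiens) for antiproliferative activity, read by CCK-8 assay, with a stated time of 72 h, tested at 8 uM (a lower number here means a weaker effect, a higher number a stronger effect of the compound at the concentration tested), compound 1 `CN1CCN(c2nc(Cl)nc3c2ncn3Cc2ccc(C(=O)Nc3ccccc3N)cc2)CC1` gives 72.8% and compound 3 `Nc1ccccc1NC(=O)c1ccc(Cn2cnc3c(Nc4cccc(OC(F)(F)F)c4)nc(Cl)nc32)cc1` gives 46.6%. Compound 2 `Nc1ccccc1NC(=O)/C=C/c1ccc(Cn2cnc3c(Nc4cccc(Cl)c4)nc(Cl)nc32)cc1` stands lowest of the three in this assay at 15.8%, beyond the scatter below both other compounds. Compound 4 `CC1CCN(c2nc(Cl)nc3c2ncn3Cc2ccc(/C=C/C(=O)Nc3ccccc3N)cc2)CC1` differs from compound 2 by 4-methylpiperidin-1-yl in place of (3-chlorophenyl)amino on an aromatic carbon. Among the compounds with values here, the only measured step that bears on this change is a number 26.2 percentage points lower from compound 1 to compound 3 (beyond the scatter), which ran in the opposite sense, a saturated cyclic amine giving way to an arylamino group on the shared core, and was a modest loss. A gain of roughly that size is therefore expected here in this assay, with the propenamide linker of compound 2 an untested variable. Compound 4 is expected to give 42%, within 18% to 68%. The expected step is a number 26.2 percentage points higher from compound 2 to compound 4 (beyond the scatter).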

Compound 4, a percentage reported as inhibition, at one concentration (the size of the read-out at that concentration, not a potency): 26.9%
Estimate against measurement, compound 4: 15.1 percentage points above; the range from low to high includes it.
By their numbers in this assay, from the lowest: compound 2; then compound 4; then compound 3; then compound 1.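

At this position, on an aromatic carbon next to the ring nitrogen, 4-methylpiperidin-1-yl in place of (3-chlorophenyl)amino gives a number 11.1 percentage points higher from compound 2 to compound 4 (beyond the scatter). With the pair of compound 1 and compound 3, this makes two pairs in which the saturated ring stands higher than the arylamino group, now also with the propenamide linker, and neither pair goes against this. No measured evidence accounts for this step.

From the compounds shown here alone, whether morpholin-4-yl or a dimethylamino group at this position would follow the same direction in this assay stays open. The compounds shown cannot separate the propenamide linker from the direct amide.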